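The compounds below may be only part of what the source reports. "The series", "measured", "known", "first", "only" and "open" are said of these compounds alone.

Measured so far:
Compound 1, `O=C([C@@H]1C[C@H](Nc2ccccc2)CN1)N1CCSC1`, gives 190 nM in an assay on a cell-free system (plasma) for inhibition of Dipeptidyl peptidase 4 (Rattus norvegicus), read by fluorescence; on this read-out lower numbers stand for stronger inhibition and higher numbers for weaker inhibition.
Compound 2, `N#Cc1ccc(N[C@@H]2CN[C@H](C(=O)N3CCSC3)C2)cc1`, gives 33.6 nM in this assay.
Compound 3, `O=C([C@@H]1C[C@H](NS(=O)(=O)c2ccccc2)CN1)N1CCSC1`, reaches only a limit in this assay, namely > 300 nM.

Compound 1 and compound 2 share one core and differ in a single place: cyano in place of hydrogen on an aromatic carbon. This change produced a 5.7-fold lower number from compound 1 to compound 2 (0.75 log units; beyond the scatter). Compound 3 carries a different core; how its core differs from that of compound 1 is not broken down here. For compound 3 the assay gives no number, only (the limit of > 300 nM in this assay, at which 1 of the 3 values shown sits).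

Compound 4, `N#Cc1ccc(S(=O)(=O)N[C@@H]2CN[C@H](C(=O)N3CCSC3)C2)cc1`, has not yet been measured in this assay. For the measured compounds named here, it differs from compound 3 by cyano in place of hydrogen on an aromatic carbon, which is the same change as the one from compound 1 to compound 2. Resting on that earlier step, a 5.7-fold lower number from compound 1 to compound 2 (0.75 log units; beyond the scatter), a step of similar direction is expected here, and since the starting point is only a limit, the outcome is uncertain. The expected step is a number no higher from compound 3 to compound 4 (the limit leaves the size open). Compound 4 is therefore estimated to give 300 nM in this assay, with a range from 80 nM to 1500 nM.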

Compound 4, half-maximal inhibitory concentration: > 300 nM
Compound 4 ended at the assay's limit; the forecaster's own chance of this, stated with the estimate: 45%; the middle value sits exactly at the limit.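

In this assay, compound 3 and compound 4 both end at a limit rather than a number, so the step between them cannot be read: the limit of > 300 nM in this assay, at which 2 of the 4 values shown sit.

The compounds shown leave open whether placing cyano on the aromatic ring of compound 3 lowers the number at all, as it did with a 5.7-fold lower number from compound 1 to compound 2 (0.75 log units; beyond the scatter).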